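Dropping the Sulfonyl from a Trifluoroacetyl Thiophene Series

The source may hold more compounds than are shown below. What is called first, only, known or untested is meant among the compounds shown, and "the series" means these compounds.

Of the compounds shown here, three of a shared core have been measured in an assay on isolated protein for inhibition of protein deacetylase HDAC6 (Homo sapiens); a lower number here means a stronger inhibitor, a higher number a weaker inhibitor. Compound 1 `O=C(c1ccc(-c2nnc(-c3ccccc3)o2)s1)C(F)(F)F` gives 330 nM in this assay. Compound 2 `O=C(c1ccc(-c2nc(CS(=O)(=O)c3cccs3)no2)s1)C(F)(F)F` gives 520 nM in this assay, a number that lies within the scatter of the number of compound 1 and so cannot be separated from it. Compound 3 `O=C(c1ccc(-c2ncc(-c3ccccc3)s2)s1)C(F)(F)F` gives 1350 nM in this assay, a higher number than that of compound 2 and beyond the scatter. Compound 2 thus stands second highest of the three numbers, with compound 1 as its nearest neighbour and compound 3 as its furthest.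

Compound 4 `O=C(c1ccc(-c2nc(Cc3cccs3)no2)s1)C(F)(F)F` has not yet been measured in this assay. It differs from compound 2 in one place: thiophen-2-yl in place of (thiophen-2-yl)sulfonyl on a saturated chain carbon bound to an aromatic carbon. For the measured compounds named here, no pair of measured compounds that differ in one place is available, so the size of this step cannot be read from a measured precedent. The remainder of the structure is unchanged, and no step beyond the scatter is expected in either direction. The step that this expectation means is a 1.2-fold lower number from compound 2 to compound 4 (0.06 log units; within the scatter). On that basis compound 4 is estimated at 450 nM in this assay, with a range from 150 nM to 1400 nM.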

Compound 4, half-maximal inhibitory concentration: 170 nM
Compound 4: the middle estimate sits 2.6-fold (0.42 log units) above what was measured; measured number inside the range.
By their numbers in this assay, from the lowest: compounds 4, 1 and 2 (each within the scatter of the next, the first and the last beyond it); then compound 3.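

For the compounds shown here, this is the first step that can be read from two measured compounds, and it shows that the saturated chain carbon bound to an aromatic carbon is sensitive to what is attached there. In this assay, thiophen-2-yl in place of (thiophen-2-yl)sulfonyl gives a 3.1-fold lower number from compound 2 to compound 4 (0.49 log units; beyond the scatter) and so goes beyond the scatter, which means that the sulfonyl is not required for inhibition at this position and that the number improves without it. No measurement shown here bears on why the number falls, so no cause can be given for the step.

What the thiophen-2-yl itself contributes stays open: how a phenyl ring, an amine or a longer chain on this carbon would compare cannot be told from the compounds shown. Nor do they tell whether a carbonyl or an ether oxygen in place of the sulfonyl would give a similar number, or whether only its complete removal brings this gain.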